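Swapping hydroxy for fluoro on the sulfonamide aryl ring

This account rests on a few compounds, and the source may have more. Where it says the series, first, only, none or still open, it means among the compounds named here.

Among the measured compounds shown here, compound 3 `O=S(=O)(Nc1ccc2oc(-c3ccccc3)nc2c1)c1cccc(O)c1` is the only compound here with a numerical result: in an assay on cells for inhibition of HSP60/HSP10 (Homo sapiens), with a stated time of 60 min (a higher number here means a weaker inhibitor, a lower number a stronger inhibitor), compound 3 gives 76000 nM. Compound 1 `O=S(=O)(Nc1ccc2oc(-c3ccccc3)nc2c1)c1ccc(Cl)c(Cl)c1` reaches only a limit of this assay, > 100000 nM. Compound 2 `Cc1cccc(S(=O)(=O)Nc2ccc3oc(-c4ccccc4)nc3c2)c1` likewise stops at a limit, > 100000 nM. Compound 4 `O=S(=O)(Nc1ccc2oc(-c3ccccc3)nc2c1)c1cccc(F)c1` differs from compound 3 by a single change (fluoro in place of hydroxy on an aromatic carbon). The measured steps that bear on it are an at least 1.3-fold lower number from compound 2 to compound 3 (0.11 log units; that floor lies within the scatter) and an at least 1.3-fold lower number from compound 1 to compound 3 (0.11 log units; that floor lies within the scatter); both are floors set by the limit of > 100000 nM in this assay, at which 2 of the 3 values shown sit, and both lie within the scatter. Removing hydroxy again is expected to push the number back toward that limit, a step of a 2.0-fold higher number from compound 3 to compound 4 (0.30 log units; within the scatter) in this assay. Compound 4 is estimated at 150000 nM, with a range from 60000 nM to 400000 nM, and a limit rather than a number is quite possible.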

Compound 4, half-maximal inhibitory concentration: > 100000 nM
Compound 4 was reported as a limit; the forecaster's own chance of this, stated with the estimate: 60%; the middle value does not contradict the limit.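

In this assay, from the compounds shown here alone, fluoro in place of hydroxy on this aromatic carbon gives an at least 1.3-fold higher number from compound 3 to compound 4 (0.11 log units; that floor lies within the scatter), so the true size of this change remains unknown. Among the groups shown on this ring, hydroxy alone gives a number, but that floor cannot separate it from fluoro. The steps from compound 1 and compound 2 to compound 4 cannot be read because both ends of each are limits: the limit of > 100000 nM in this assay, at which 3 of the 4 values shown sit.

Going by these compounds, whether an amine or a carboxylic acid in place of hydroxy would also give a number remains open.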